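Nitro to methoxy on the aryl ring, second pair

The compounds below may be only part of what the source reports. "The series", "measured", "known", "first", "only" and "open" are said of these compounds alone.

Measured compounds:
Compound 1 `O=C(Nn1c(-c2cccc([N+](=O)[O-])c2)nc2c(-c3ccco3)n[nH]c2c1=O)c1cccnc1`: 11.7%
Compound 2 `COc1cccc(-c2nc3c(-c4ccco4)n[nH]c3c(=O)n2NC(=O)c2cccnc2)c1`: 12.8%
Compound 3 `O=C(Nn1c(-c2cccc([N+](=O)[O-])c2)nc2c(-c3cccc(Cl)c3)n[nH]c2c1=O)c1ccccc1`: 89.8%

In a functional assay on HT-29 cells (Homo sapiens) for cytotoxicity, read by sulforhodamine B assay, with a stated time of 2 days, tested at 100 uM (on this read-out higher numbers stand for more inhibition at the one concentration tested (going by the name of the read-out) and lower numbers for less inhibition), compound 1 gives 11.7% and compound 2 gives 12.8%. The change between them is methoxy in place of nitro on an aromatic carbon. The step it made, a number 1.1 percentage points higher from compound 1 to compound 2 (within the scatter), is small. Compound 3 gives 89.8% in this assay, the highest of the three, and its distance to compound 1 and to compound 2 is beyond the scatter in both cases. The difference between the core of compound 3 and the core of compound 1 is not broken down here.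

Compound 4 `COc1cccc(-c2nc3c(-c4cccc(Cl)c4)n[nH]c3c(=O)n2NC(=O)c2ccccc2)c1` is still to be measured in this assay. It differs from compound 3 by methoxy in place of nitro on an aromatic carbon, the same change as from compound 1 to compound 2, made at a place described in the same words. Because the earlier step of a number 1.1 percentage points higher from compound 1 to compound 2 (within the scatter) stayed within the scatter, a similarly small step is expected here, a number 4.8 percentage points lower from compound 3 to compound 4 (within the scatter). The expectation rests on a single prior pair, measured at the low end of the read-out, so the range is kept wide. Compound 4 is estimated at 85%, between 60% and 97%.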

Compound 4, a percentage reported as inhibition, at one concentration (the size of the read-out at that concentration, not a potency): 91%
Beside the measured number, compound 4's estimate is 6 percentage points below it; the range from low to high includes it.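

In this assay, the change from 3-nitrophenyl to 3-methoxyphenyl gives a number 1.2 percentage points higher from compound 3 to compound 4 (within the scatter), and the step carries from one core to the other without a difference between the two pairs: the same change on two cores in this assay, a number 1.1 percentage points higher (within the scatter) from compound 1 to compound 2 and a number 1.2 percentage points higher (within the scatter) from compound 3 to compound 4, 0.1 percentage points apart, within the scatter of two such steps

On these two cores the swap leaves the number in place, whether the pair sits low on the read-out, as compound 1 and compound 2 do, or high, as compound 3 and compound 4 do. This does not show that potency is unchanged, as each number is only the size of the inhibition at one concentration, and two cores do not make a rule for the series.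

On these data alone, whether an amine, a carboxylic acid or a longer chain such as butoxy would keep the number in place of the nitro group remains open. Also open, as far as these compounds go, is which of the places that differ between the core of compound 1 and the core of compound 3 carries the distance between their numbers.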